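The compounds below may be only part of what the source reports. "The series", "measured", "known", "first", "only" and "open" are said of these compounds alone.

Working notes on the amide series in a functional assay on the whole organism for inhibition, with Rattus norvegicus as the target, read by paw edema, at a dose of 100 mg/kg by the oral route; on this read-out higher numbers stand for more inhibition at the one dose given (going by the name of the read-out) and lower numbers for less inhibition. Compound 2 `Cc1ccc(NC(=O)c2c(O)c3cccnc3n(-c3ccccc3)c2=O)cc1` gives -3.5%, the smallest of the three numbers, yet its steps to both neighbours fall within the scatter: a number 5.1 percentage points lower from compound 1 to compound 2 (within the scatter) and a number 8.1 percentage points higher from compound 2 to compound 3 (within the scatter). Compound 1 `O=C(NCc1ccccc1)c1c(O)c2cccnc2n(-c2ccccc2)c1=O` gives 1.6%, and compound 3 `O=C(Nc1nccs1)c1c(O)c2cccnc2n(-c2ccccc2)c1=O` gives 4.6%; between them a number 3 percentage points higher from compound 1 to compound 3 (within the scatter). Nothing among the three measured compounds separates beyond the scatter, so no ordering can be claimed.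

Compound 4 `COc1ccc(NC(=O)c2c(O)c3cccnc3n(-c3ccccc3)c2=O)cn1` is the next member. Relative to compound 2 the change is 6-methoxypyridin-3-yl in place of 4-methylphenyl on an amide-type nitrogen. Among the compounds with values here, the one measured step that bears on it is the exchange at the same amide-type nitrogen from 4-methylphenyl to 1,3-thiazol-2-yl, a number 8.1 percentage points higher from compound 2 to compound 3 (within the scatter), within the scatter; the benzyl cases add a number 5.1 percentage points lower from compound 1 to compound 2 (within the scatter) and a number 3 percentage points higher from compound 1 to compound 3 (within the scatter), also within the scatter. A step beyond the scatter is therefore not expected, and the step expected from this change is a number 5.5 percentage points higher from compound 2 to compound 4 (within the scatter). Compound 4 is estimated at 2%, with a range from -9% to 13%.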

Compound 4, a percentage reported as inhibition, in the whole organism at one dose (the size of the read-out at that dose, not a potency): 13.1%
Estimate against measurement, compound 4: 11.1 percentage points below, outside the stated range (above it).
By their numbers in this assay, from the lowest: compounds 2, 1, 3 and 4 (each within the scatter of the next, the first and the last beyond it).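

At the amide-type nitrogen, in this assay, 6-methoxypyridin-3-yl gives the first separations beyond the scatter in this series: a number 16.6 percentage points higher from compound 2 to compound 4 (beyond the scatter) and a number 11.5 percentage points higher from compound 1 to compound 4 (beyond the scatter), so the group on this nitrogen can move the read-out at this dose. The separation is not general, since the same exchange against 1,3-thiazol-2-yl gives a number 8.5 percentage points higher from compound 3 to compound 4 (within the scatter), and no order can be claimed for that pair. No measurement on hand accounts for these steps.

From the compounds shown here alone, the entering group brings a ring nitrogen and a methoxy together, so it stays open which of the two carries the step; a plain pyridin-3-yl and a 4-methoxyphenyl on this nitrogen would separate them. Going by these compounds, how a 6-aminopyridin-3-yl would read here also stays open.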